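Aryl swap on the ring amine nitrogen

The compounds below may be only part of what the source reports. "The series", "measured", "known", "first", "only" and "open" are said of these compounds alone.

The three measured compounds share one core and differ only in the aryl group on the ring amine nitrogen. In a functional assay on CHO cells with adenosine receptor A1 (Homo sapiens) as the target, read by cAMP accumulation and immunoassay, with a stated time of 6 min, tested at 0.1 uM (on this read-out higher numbers stand for a weaker effect at the one concentration tested and lower numbers for a stronger effect), compound 1 `Nc1scc(CN2CCN(c3cccc(Cl)c3Cl)CC2)c1C(=O)c1ccc(Cl)cc1` gives 3.2%. Compound 2 `Nc1scc(CN2CCN(c3cc(Cl)cc(Cl)c3)CC2)c1C(=O)c1ccc(Cl)cc1` gives -22% in this assay, the lowest of the three numbers. Compound 3 `Nc1scc(CN2CCN(c3ccc(F)cc3Cl)CC2)c1C(=O)c1ccc(Cl)cc1` gives -6.2% in this assay. The steps among them are a number 25.2 percentage points lower from compound 1 to compound 2 (beyond the scatter), a number 9.4 percentage points lower from compound 1 to compound 3 (within the scatter) and a number 15.8 percentage points higher from compound 2 to compound 3 (beyond the scatter).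

Compound 4 `Nc1scc(CN2CCN(c3ccc([N+](=O)[O-])cc3)CC2)c1C(=O)c1ccc(Cl)cc1` has not yet been measured. Against compound 2 the change is 4-nitrophenyl in place of 3,5-dichlorophenyl on an amine nitrogen in a ring. Going by the values given here, no measured step involves a nitro group, so the three known steps bear only indirectly: they show that compound 2 holds the low end, and the one step that starts from it, a number 15.8 percentage points higher from compound 2 to compound 3 (beyond the scatter), leads to a higher number, as does the gap to compound 1. A modest step upward is therefore expected, a number 16 percentage points higher from compound 2 to compound 4 (beyond the scatter). Compound 4 is estimated at -6% in this assay, within a range of -26% to 14%.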

Compound 4, a percentage reported as activity, at one concentration (the size of the read-out at that concentration, not a potency): -13%
Compound 4: middle estimate off by 7 percentage points, on the high side, within the range that was stated.
By their numbers in this assay, from the lowest: compounds 2, 4, 3 and 1 (each within the scatter of the next, the first and the last beyond it).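

In this assay, replacing the chlorinated aryl groups with 4-nitrophenyl, which brings hydrogen-bond acceptors to a group that had none in 3,5-dichlorophenyl, leaves the read-out within the scatter of two earlier compounds: a number 9 percentage points higher from compound 2 to compound 4 (within the scatter), and a number 6.8 percentage points lower from compound 3 to compound 4 (within the scatter). So at this position, an aryl group without chlorine is compatible with a number in the same range, while the difference from 2,3-dichlorophenyl remains measurable, a number 16.2 percentage points lower from compound 1 to compound 4 (beyond the scatter). Nothing available explains these differences in terms of the groups involved.

As far as these compounds go, it remains open whether a 4-aminophenyl, 4-carboxyphenyl or 4-methoxyphenyl group, or an unsubstituted phenyl, would fall in the same range. With readings at a single concentration, the potency of these compounds also remains open.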